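The source may report more compounds than this note shows. Statements on the series, on what has been measured and on what is new or still open speak of the compounds shown alone.

compound 1 `c1ccc2c(c1)CN[C@@H](CN(CC1CCNCC1)[C@H]1CCCc3cccnc31)C2` 86%
compound 2 `c1cnc2c(c1)CCC[C@@H]2N(CCCN1CCNCC1)Cc1cc2ccccc2cn1` 66%
compound 3 `NC(=O)N1CCN(CCCN(C[C@H]2Cc3ccccc3CN2)[C@H]2CCCc3cccnc32)CC1` 79%

In an ADME assay on microsomes from liver (Homo sapiens) for metabolic stability, read by LC-MS, with a stated time of 10 min, tested at 0.5 uM (a higher number here means that more of the compound is left, a lower number that less of the compound is left), compound 2 stands lowest of the three, beyond the scatter from both compound 3 and compound 1. The unmeasured compound 4 `c1cnc(CN(CCCN2CCNCC2)[C@H]2CCCc3cccnc32)nc1` differs from compound 2 by pyrimidin-2-yl in place of isoquinolin-3-yl on a saturated chain carbon bound to an amine nitrogen.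

Among the compounds with values here, no measured step makes this exchange. Within the data shown here, the only step available is a number 7 percentage points lower from compound 1 to compound 3 (within the scatter), which swaps other groups and gives only a loose guide to size. Of the three measured compounds, only compound 2 carries isoquinolin-3-yl. Without it, compound 1 gives 86% and compound 3 gives 79%, though both also differ from compound 2 elsewhere. A modest rise in this assay is therefore expected, with low confidence. The expected change is a number 10 percentage points higher from compound 2 to compound 4 (within the scatter), an estimate resting on very few data. For compound 4 the estimated value is 76%, with an expected range of 60% to 90% for the measurement.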

Compound 4, percent of the compound remaining: 100%
Compound 4: the middle estimate sits 24 percentage points below what was measured; the measured number lies above the stated range.
By their numbers in this assay, from the lowest: compound 2; then compounds 3 and 1 (each within the scatter of the next); then compound 4.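

In this assay the exchange of isoquinolin-3-yl for pyrimidin-2-yl on a saturated chain carbon bound to an amine nitrogen gives a number 34 percentage points higher from compound 2 to compound 4 (beyond the scatter) in a single change. Within the data shown here, this is the first step that lies beyond the scatter, so the group at this place can move the percentage remaining substantially. Among these compounds, the only earlier step, a number 7 percentage points lower from compound 1 to compound 3 (within the scatter) at a different place, did not show this.

The step replaces a two-ring group with a smaller one-ring group and also adds a ring nitrogen, so the compounds shown cannot separate these changes, and a phenyl or pyridin-2-yl group at this place would bear on that question. No evidence on the cause of the step is available here.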